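Notes on a 4-hydroxyphenyl swap in the series

The source may report more compounds than this note shows. Statements on the series, on what has been measured and on what is new or still open speak of the compounds shown alone.

Measured so far:
Compound 1 `COc1ccc(C=c2s/c(=C3\C(=O)Nc4cc(F)ccc43)n(CCN(C)C)c2=O)cc1`: 2200 nM
Compound 2 `CN(C)CCn1c(=O)c(=Cc2ccc(O)cc2)s/c1=C1\C(=O)Nc2ccc(F)cc21`: 1270 nM
Compound 3 `CCN(CC)CCCn1c(=O)c(=Cc2cc(OC)c(OC)c(OC)c2)s/c1=C1\C(=O)Nc2ccc(C)cc21`: 2670 nM

In a functional assay on NCI-H460 cells (Homo sapiens) for inhibition, read by MTT assay, with a stated time of 72 h (on this read-out lower numbers stand for stronger inhibition and higher numbers for weaker inhibition), compound 3 stands at the highest of the three numbers. Compound 1 sits within the scatter of compound 3, so no order between them can be read, while compound 2 lies beyond the scatter at a lower number. Compound 4 `CCN(CC)CCCn1c(=O)c(=Cc2ccc(O)cc2)s/c1=C1\C(=O)Nc2ccc(C)cc21` has not been measured. It differs from compound 3 in one place: 4-hydroxyphenyl in place of 3,4,5-trimethoxyphenyl on a double-bonded chain carbon bound to an aromatic carbon. Compound 2 carries the same 4-hydroxyphenyl group, and its low number is the only pointer available. The step of a 1.8-fold lower number from compound 3 to compound 4 (0.25 log units; within the scatter) is expected to run downward, small enough that it may sit within the scatter. Compound 4 is estimated at 1500 nM, with a range from 700 nM to 3500 nM.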

Compound 4, half-maximal inhibitory concentration: 260 nM
Compound 4: middle estimate off by 5.8-fold (0.76 log units), on the high side; the measured number lies below the stated range.
By their numbers in this assay, from the lowest: compound 4; then compounds 2, 1 and 3 (each within the scatter of the next, the first and the last beyond it).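

In this assay, going by these compounds alone, 4-hydroxyphenyl in place of 3,4,5-trimethoxyphenyl on a double-bonded chain carbon bound to an aromatic carbon gives a 10-fold lower number from compound 3 to compound 4 (1.01 log units; beyond the scatter), the first one-place pair. It shows that a change at this place alone can produce a large step. Nothing available bears on why the step is this large.

Still open, going by these compounds, is whether the step follows from the hydroxyl group or from the removal of the methoxy groups. A plain phenyl or 4-aminophenyl group at this place would help separate the two.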